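The compounds below may be only part of what the source reports. "The series", "measured", "known", "first", "only" and "open" are said of these compounds alone.

For the measured compounds named here, in a functional assay on CHO cells for antagonist activity at sphingosine 1-phosphate receptor 2 (Homo sapiens), read by scintillation counting and GTPgammaS binding, with a stated time of 4 h, in the presence of a further agent that is not named here (on this read-out lower numbers stand for stronger inhibition and higher numbers for weaker inhibition), compound 2 `CCOC(=O)c1cc(C)cc(NNC(=O)Nc2cc(Cl)nc(Cl)c2)n1` gives 2.1 nM, the lower of the two numbers measured so far. Compound 1 `Cc1cc(NNC(=O)Nc2cc(Cl)nc(Cl)c2)ncc1N(C)C` gives 5.3 nM, and the gap between the two lies beyond the usual scatter. Compound 3 `Cc1cc(NNC(=O)Nc2cc(Cl)nc(Cl)c2)nc(-c2ccc(F)cc2)c1` has not yet been measured; it differs from compound 2 in one place: 4-fluorophenyl in place of ethoxycarbonyl on an aromatic carbon. Going by the values given here, no measured pair shows this change, so its effect cannot be read from the data; a small step in either direction, possibly not beyond the scatter, is expected. For compound 3 the estimate is 4 nM, within 1.3 nM to 12 nM. This corresponds to an expected step of a 1.9-fold higher number from compound 2 to compound 3 (0.28 log units; within the scatter).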

Compound 3, half-maximal inhibitory concentration: 6.2 nM
Beside the measured number, compound 3's estimate is 1.6-fold (0.19 log units) below it, and the stated range covers the measured number.
By their numbers in this assay, from the lowest: compound 2; then compounds 1 and 3 (each within the scatter of the next).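

In this assay, replacing ethoxycarbonyl with 4-fluorophenyl on this aromatic carbon next to the ring nitrogen gives a 3.0-fold higher number from compound 2 to compound 3 (0.47 log units; beyond the scatter), a modest change. This position therefore accepts a larger carbon-only aromatic ring, and inhibition remains without the hydrogen-bond acceptors of ethoxycarbonyl. No measurement here explains the step. The compounds shown cannot separate the loss of ethoxycarbonyl from the arrival of 4-fluorophenyl. A plain phenyl, a carboxylic acid or a primary amide at this position would test how much each part matters.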